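The source may report more compounds than this note shows. Statements on the series, on what has been measured and on what is new or still open speak of the compounds shown alone.

Four compounds built on one shared core are compared in a functional assay on MCF7 cells (Homo sapiens) for antiproliferative activity, read by MTT assay, with a stated time of 48 h; a lower number here means a stronger inhibitor, a higher number a weaker inhibitor. Compound 1 `CCOC(=O)CNc1nc(Nc2cccc(OC)c2)ncc1[N+](=O)[O-]` gives 35800 nM in this assay. Compound 3 `CCOC(=O)CNc1nc(NCc2ccccc2)ncc1[N+](=O)[O-]` gives 52400 nM. Compound 2 `CCOC(=O)CN(Cc1ccccc1)c1nc(NCc2ccccc2)ncc1[N+](=O)[O-]` reaches only a limit of the assay, > 100000 nM, so its place is a floor rather than a number. That is the limit of > 100000 nM in this assay, at which 1 of the 3 values shown sits. The unmeasured compound 4 `CCOC(=O)CN(Cc1ccccc1)c1nc(Nc2cccc(OC)c2)ncc1[N+](=O)[O-]` differs from compound 2 in one place: 3-methoxyphenyl in place of benzyl on a nitrogen on an aromatic ring.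

For the measured compounds named here, two measured steps bear on this comparison. Going by the values given here, the change is the reverse of the one seen between compound 1 and compound 3, where a 1.5-fold higher number from compound 1 to compound 3 (0.17 log units; within the scatter). The other step, an at least 1.9-fold lower number from compound 2 to compound 3 (0.28 log units; that floor lies within the scatter), removes a benzyl from the other nitrogen instead and rests on a floor, so it speaks less directly. Turning the first step round, putting 3-methoxyphenyl in place of benzyl is expected to give a somewhat lower number, if anything, and nothing beyond the scatter, starting from a compound that already sits at the limit. Compound 4 is therefore estimated at 90000 nM, with a range from 40000 nM to 200000 nM. That amounts to an expected step of an at least 1.1-fold lower number from compound 2 to compound 4 (0.04 log units; that floor lies within the scatter), with a fair chance that the assay again reports only a limit.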

Compound 4, half-maximal inhibitory concentration: > 100000 nM
Compound 4: no number, only a limit; the forecaster's own chance of this, stated with the estimate: 55%; middle value at least 1.1-fold (0.04 log units) away from the limit.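

In this assay, putting benzyl in place of hydrogen on a nitrogen on an aromatic ring now has a size that stands clear of the usual scatter: it gives an at least 2.7-fold higher number from compound 1 to compound 4 (0.44 log units; beyond the scatter). The same change can also now be followed with two different groups elsewhere on the shared core, benzylamino in compound 3 and (3-methoxyphenyl)amino in compound 1: the same change on two cores in this assay, an at least 1.9-fold lower number (0.28 log units; that floor lies within the scatter) from compound 2 to compound 3 and an at least 2.7-fold lower number (0.44 log units; beyond the scatter) from compound 4 to compound 1; the limit leaves it open whether they differ Compound 2 and compound 4 are both limits rather than numbers, and the step between them cannot be read: the limit of > 100000 nM in this assay, at which 2 of the 4 values shown sit.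

As far as these compounds go, it therefore remains open whether 3-methoxyphenyl and benzyl differ at all in compounds that also carry this added benzyl, and the near-equal values of compound 1 and compound 3 give no sign of a difference without it. Also open, from the compounds shown here alone, is whether a methyl in place of the added benzyl would raise the number as well, and whether a carboxylic acid in place of the ethyl ester would change the picture on either core.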